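A few compounds are considered here, and "the series" means these few. Any claim that something is new, unique, unknown or untested is made for them only; others in the source may bear on it.

In an ADME assay (liver) for metabolic stability, with Liver microsome (Homo sapiens) as the target, using microsomes, with a stated time of 30 min, tested at 1 uM (a higher number here means that more of the compound is left, a lower number that less of the compound is left), compound 1 `N#C/N=C(\NCc1ccc(S(=O)(=O)c2ccccc2)cc1)Nc1cccnc1` gives 83%, compound 3 `O=C(NCc1ccc(S(=O)(=O)c2ccccc2)cc1)c1cc2cnccc2[nH]1` gives 75% and compound 2 `COc1cccc(S(=O)(=O)c2ccc(CN/C(=N\C#N)Nc3ccncc3)cc2)c1` gives 55%, the lowest of the three numbers, with both others higher beyond the scatter. Compound 4 `N#C/N=C(\NCc1ccc(S(=O)(=O)c2cccc(OC(F)(F)F)c2)cc1)Nc1ccncc1` differs from compound 2 by trifluoromethyl in place of methyl on an oxygen on an aromatic ring. For the measured compounds named here, no measured pair shows this change, so any expectation is loose. It leans on compound 2, at 55%, standing under compound 1 and compound 3, neither of which carries the methoxy. An upward move is expected, with an estimated a number 13 percentage points higher from compound 2 to compound 4 (beyond the scatter). For compound 4 the expected value is 68%, with an estimated range of 50% to 85%.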

Compound 4, percent of the compound remaining in the Liver microsome assay: 45%
Estimate against measurement, compound 4: 23 percentage points above; the measured number lies below the stated range.
By their numbers in the Liver microsome assay, from the lowest: compounds 4 and 2 (each within the scatter of the next); then compounds 3 and 1 (each within the scatter of the next).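

In the Liver microsome assay, trifluoromethyl in place of methyl on an oxygen on an aromatic ring gives a number 10 percentage points lower from compound 2 to compound 4 (within the scatter), so this exchange does not separate the two compounds on that read-out. For the compounds shown here, the first step at this position therefore shows a methoxy and a trifluoromethoxy reading alike there. In a physicochemical assay for solubility, with a stated time of 24 h (on this read-out higher numbers stand for higher solubility and lower numbers for lower solubility), compound 2 gives 51000 nM and compound 4 gives 16000 nM, and the same exchange does separate them: the measured solubility of compound 2, 51000 nM, and of compound 4, 16000 nM, a 3.2-fold lower number (0.50 log units; beyond the scatter)

Going by these compounds, what remains open is how a longer chain on that oxygen, or an amine in place of the methoxy, would read in either assay. On these data alone, whether the position itself matters also remains open.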